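Branched arms on the sulfonyl nitrogen of a sulfamoylurea

A few compounds are considered here, and "the series" means these few. Any claim that something is new, unique, unknown or untested is made for them only; others in the source may bear on it.

Measured so far:
compound 1, `CCCCN(C)S(=O)(=O)NC(=O)Nc1c(C(C)C)cccc1C(C)C` — an assay on liver for inhibition of sterol O-acyltransferase 1 (Rattus norvegicus), using microsomes; on this read-out higher numbers stand for weaker inhibition and lower numbers for stronger inhibition: 2300 nM
compound 2, `CCCN(CCC)S(=O)(=O)NC(=O)Nc1c(C(C)C)cccc1C(C)C` — this assay: 1100 nM
compound 3, `CCCCN(CCCC)S(=O)(=O)N(C)C(=O)Nc1c(C(C)C)cccc1C(C)C` — this assay: > 5000 nM, which is a limit of the assay and not a number

Compound 2 gives the lowest of the two numbers reported, with compound 1 nearest to it. The step between them, a 2.1-fold lower number from compound 1 to compound 2 (0.32 log units; beyond the scatter), replaces butyl(methyl)amino with dipropylamino on the sulfonyl sulfur. For compound 3 only a limit is reported (the limit of > 5000 nM in this assay, at which 1 of the 3 values shown sits); compound 3 also carries a methyl on the urea nitrogen, so its value cannot be read as a step from compound 2 alone.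

Compound 4, `CC(C)CN(CC(C)C)S(=O)(=O)NC(=O)Nc1c(C(C)C)cccc1C(C)C`, has not yet been measured. It differs from compound 2 in one place: diisobutylamino in place of dipropylamino on a sulfonyl sulfur. For the measured compounds named here, the only measured step that bears on it is the one from compound 1 to compound 2, which was modest and went toward lower numbers when the amino substituents were made longer and more alike. Going by the values given here, the change to diisobutylamino again lengthens both arms, now with branching, for which no measured step exists.

A modest step in the same direction, or none beyond the scatter, is therefore expected. Compound 4 is estimated at 800 nM, with a range from 300 nM to 2500 nM, which corresponds to an expected step of a 1.4-fold lower number from compound 2 to compound 4 (0.14 log units; within the scatter).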

Compound 4, half-maximal inhibitory concentration: 420 nM
Beside the measured number, compound 4's estimate is 1.9-fold (0.28 log units) above it; the range from low to high includes it.
By their numbers in this assay, from the lowest: compound 4; then compound 2; then compound 1. At a limit, above all of these: compound 3.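

In this assay, the position on the sulfonyl sulfur gives a second step toward lower numbers (a 2.6-fold lower number from compound 2 to compound 4 (0.42 log units; beyond the scatter)), so the trend from compound 1 to compound 2 continues when the arms become diisobutylamino. Taken directly, replacing butyl(methyl)amino with diisobutylamino spans the widest measured range at this place (a 5.5-fold lower number from compound 1 to compound 4 (0.74 log units; beyond the scatter)), and it shows that branched arms are accepted here, which the earlier compounds with unbranched arms could not show. Nothing among the data shown explains why diisobutylamino gives the lower number.

Compound 4 carries more carbon than compound 2 as well as branching, so these two changes cannot be told apart, and compound 3 does not settle the matter: it has a methyl on the urea nitrogen as well as dibutylamino, and its value (> 5000 nM) is a limit of the assay and not a number. Going by these compounds, how the trend continues with bulkier neopentyl arms, or with the nitrogen held in a ring such as piperidine, remains open.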